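From an ester side chain to a free acid

This account rests on a few compounds, and the source may have more. Where it says the series, first, only, none or still open, it means among the compounds named here.

Compound 1 `COc1ccc(-c2oc3c(CC=C(C)C)c(OCCCOC(=O)CCCC(=O)O)cc(O)c3c(=O)c2OCCCOC(=O)CCCC(=O)O)cc1`, 2200 nM
Compound 2 `COc1ccc(-c2oc3c(CC=C(C)C)c(OCCOC(=O)CCCC(=O)O)cc(O)c3c(=O)c2OCCOC(=O)CCCC(=O)O)cc1`, 3000 nM
Compound 3 `CCOC(=O)C(C)Oc1cc(O)c2c(=O)c(O)c(-c3ccc(OC)cc3)oc2c1CC=C(C)C`, > 100000 nM

In a functional assay on MCF7 cells (Homo sapiens) for cytotoxicity, read by MTT assay (a lower number here means a stronger inhibitor, a higher number a weaker inhibitor), compound 1 gives 2200 nM and compound 2 gives 3000 nM, two values that lie within the scatter of each other. Within the data shown here, for compound 3 the measurement returned only a limit, > 100000 nM, so it stands apart from the other two as the one compound without a number. the limit of > 100000 nM in this assay, at which 1 of the 3 values shown sits, is where compound 3 sits.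

Compound 4 `COc1ccc(-c2oc3c(CC=C(C)C)c(OCC(=O)O)cc(O)c3c(=O)c2O)cc1` has not yet been measured. It keeps the shared core of compound 3 and changes one group on the oxygen of the aromatic ring:

carboxymethyl in place of 1-(ethoxycarbonyl)ethyl on an oxygen on an aromatic ring

Among the measured compounds shown here, no step between measured compounds is known for this kind of change, and a step out of a limit cannot be sized. Compound 4 is expected to be a stronger inhibitor than the limit of compound 3 allows one to say, though not by a large margin, and the estimated step is an at least 2.5-fold lower number from compound 3 to compound 4 (0.39 log units; beyond the scatter). For compound 4 the estimate in this assay is 40000 nM, with a range from 8000 nM to 150000 nM.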

Compound 4, half-maximal inhibitory concentration: > 100000 nM
Compound 4 was reported as a limit; the forecaster's own chance of this, stated with the estimate: 45%; at least 2.5-fold (0.39 log units) between middle value and limit.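

Among these compounds, no step from compound 3 to compound 4 can be read, because each of the two is reported only as a limit, not as a number: the limit of > 100000 nM in this assay, at which 2 of the 4 values shown sit.

As far as these compounds go, whether carboxymethyl in place of 1-(ethoxycarbonyl)ethyl changes the strength of inhibition at all stays open.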